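Pyrazolyl chalcones in ACHN cytotoxicity: second methoxy on aryl

The source may report more compounds than this note shows. Statements on the series, on what has been measured and on what is new or still open speak of the compounds shown alone.

Measured so far:
compound 1 `COc1ccc(-c2cc(/C=C/C(=O)c3ccc(N)cc3)[nH]n2)cc1` — 2%
compound 2 `COc1ccc(C(=O)/C=C/c2cc(-c3cc(OC)c(OC)c(OC)c3)n[nH]2)cc1OC` — -95%

Two compounds of this series have been run in a functional assay on ACHN cells (Homo sapiens) for cytotoxicity, read by sulforhodamine B assay, with a stated time of 48 h, tested at 10 uM; a higher number here means a weaker effect of the compound at the concentration tested, a lower number a stronger effect. Compound 1 stands highest of the two numbers; in this assay compound 1 gives 2%, which is a weak effect at the concentration tested. Within the data shown here, its only neighbour, compound 2, gives -95% in this assay, a number far lower and beyond the scatter, so compound 2 shows a strong effect where compound 1 shows next to none. Among the measured compounds shown here, no step between these two is computed here, as they differ in more than one place, and their two values are all that can be said of the pair.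

The next compound, compound 3 `COc1ccc(-c2cc(/C=C/C(=O)c3ccc(N)cc3)[nH]n2)cc1OC`, is not yet measured. It differs from compound 1 by a single change: methoxy in place of hydrogen on an aromatic carbon. For the measured compounds named here, no computed step is available for this kind of change, so the direction and size of the effect in this assay rest on the two values alone. The second methoxy brings compound 3 closer in substitution to compound 2, whose value is -95%, but the rest of the molecule follows compound 1, whose value is 2%. A modest step downward, toward a stronger effect, is expected, with wide uncertainty: the estimated step is a number 17 percentage points lower from compound 1 to compound 3 (beyond the scatter). For compound 3 the expected value in this assay is -15%, estimated to lie between -75% and 15%.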

Compound 3, a percentage reported as activity, at one concentration (the size of the read-out at that concentration, not a potency): -82%
Compound 3: the middle estimate sits 67 percentage points above what was measured; measured number outside the range, below it.
By their numbers in this assay, from the lowest: compound 2; then compound 3; then compound 1.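

In this assay, methoxy in place of hydrogen on an aromatic carbon, ortho to a methoxy group and meta to a large group, gives a number 84 percentage points lower from compound 1 to compound 3 (beyond the scatter). With everything else in compound 1 kept, this one position therefore separates next to no effect from a strong effect at the concentration tested, which the earlier pair could not show, as compound 1 and compound 2 differ in more than one place. Nothing at hand bears on why this single change has a step of this size.

The compounds shown leave open whether the step belongs to methoxy itself or to any group at this place, a question that ethoxy, hydroxy or fluorine there would address. Also open, on these data alone, is whether the amine on the other aromatic ring contributes to the strong effect of compound 3, which a compound carrying a carboxylic acid or a plain hydrogen in its place, with the rest of compound 3 unchanged, would test.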